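The source may hold more compounds than are shown below. What is called first, only, known or untested is meant among the compounds shown, and "the series" means these compounds.

Compound 1 `COc1cccc2cc(C(=O)Nc3c(C#N)ncn3-c3ccc(C#N)cc3)c(=N)oc12` gives 10% in an assay on HEK293 cells for displacement of a labelled ligand from adenosine receptor A2b (Homo sapiens), read by scintillation counting, with a stated time of 30 min, tested at 10 uM (a lower number here means less inhibition, a higher number more inhibition at the concentration tested (going by the name of the read-out)), the second highest of the three numbers measured. Compound 3 `COCCNC(=O)c1cc2cc(Cl)ccc2oc1=N` gives 9% in this assay, a number within the scatter of compound 1, so the two cannot be ordered. Compound 2 `COc1cccc2cc(C(=O)NC3CCCC3)c(=N)oc12` gives 47% in this assay, a number beyond the scatter away from both of the others. Compound 4 `COc1cccc2cc(C(=O)Nc3c(C#N)ncn3-c3ccccc3)c(=N)oc12` differs from compound 1 by hydrogen in place of cyano on an aromatic carbon. Going by the values given here, no step between two measured compounds shows what this change does, so the expectation rests on compound 1 alone. The expected step is a number 2 percentage points higher from compound 1 to compound 4 (within the scatter), none beyond the scatter. Compound 4 is therefore estimated to give 12% in this assay, between 0% and 30%.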

Compound 4, a percentage reported as inhibition, at one concentration (the size of the read-out at that concentration, not a potency): 9%
For compound 4 the middle estimate is 3 percentage points above the measured one, within the range that was stated.
By their numbers in this assay, from the lowest: compounds 3, 4 and 1 (each within the scatter of the next); then compound 2.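

The change from 4-cyanophenyl to phenyl, with hydrogen in place of cyano on the aromatic carbon para to a large group, gives a number 1 percentage points lower from compound 1 to compound 4 (within the scatter) in this assay. The cyano group at this position therefore has no effect that this assay can resolve, at least with inhibition this low on this compound pair. No evidence is available to explain this result.

As far as these compounds go, whether an amine or a carboxylic acid at the same place would give a different number remains open. So does whether the same change would read alike on a compound with a higher number.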